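A Saturated Bicyclic Group Replaces the Dichlorophenylethyl Chain

A few compounds are considered here, and "the series" means these few. Any claim that something is new, unique, unknown or untested is made for them only; others in the source may bear on it.

Compound 3 `Clc1ccc(CCCN2CCC(COC(c3ccccc3)c3ccccc3)CC2)cc1Cl` stands highest of the three compounds tested in a functional assay on cells (T-cell line, Homo sapiens) for inhibition; a higher number here means a weaker inhibitor, a lower number a stronger inhibitor: compound 3 gives 2200 nM. Compound 1 `COc1ccc(CCCN2CCC(COCc3ccc(Cl)c(Cl)c3)CC2)cc1` gives 200 nM and compound 2 `COc1ccc(CCCN2CCC(CCC(c3ccccc3)c3ccccc3)CC2)cc1` gives 200 nM, each of them beyond the scatter from compound 3 and on the stronger side, so compound 3 is the weakest inhibitor here. Compound 4 `c1ccc(C(OCC2CCN(CC3CCc4ccccc4C3)CC2)c2ccccc2)cc1` has not yet been measured in this assay. It differs from compound 3 in one place: 1,2,3,4-tetrahydronaphthalen-2-yl in place of 2-(3,4-dichlorophenyl)ethyl on a saturated chain carbon bound to an amine nitrogen in a ring. Going by the values given here, no measured pair shows this change, and the data give no direct guide to its size. The expected step of a 2.8-fold lower number from compound 3 to compound 4 (0.44 log units; beyond the scatter) points toward a lower number, but only moderately. Compound 4 is therefore estimated at 800 nM, with a range from 200 nM to 3000 nM.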

Compound 4, half-maximal inhibitory concentration: 5600 nM
Compound 4: middle estimate off by 7.0-fold (0.85 log units), on the low side; measured number outside the range, above it.
By their numbers in this assay, from the lowest: compounds 1 and 2 (each within the scatter of the next); then compound 3; then compound 4.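

Putting 1,2,3,4-tetrahydronaphthalen-2-yl in place of 2-(3,4-dichlorophenyl)ethyl on a saturated chain carbon bound to an amine nitrogen in a ring gives a 2.5-fold higher number from compound 3 to compound 4 (0.41 log units; beyond the scatter) in this assay. Going by these compounds alone, this is the first single-place step at this position, and it shows that a change which removes both chlorine atoms and adds a non-aromatic ring weakens inhibition modestly. No evidence on the cause is available.

Going by these compounds, it remains open whether the loss follows from the missing chlorine or from the added ring. On these data alone, it also remains open whether a 1,2,3,4-tetrahydronaphthalen-2-yl group carrying chlorine, or a longer chain, would regain inhibition.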